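The source may report more compounds than this note shows. Statements on the series, on what has been measured and on what is new or still open speak of the compounds shown alone.

Measured so far in a functional assay on SGC-7901 cells (Homo sapiens) for antiproliferative activity, read by MTT assay, with a stated time of 72 h; a lower number here means a stronger inhibitor, a higher number a weaker inhibitor:
- compound 1 `COc1ccc(-c2ccc3ncn(-c4cc(OC)c(OC)c(OC)c4)c3c2)cc1F`: 430 nM
- compound 2 `COc1cc(-n2cnc3ccc(-c4cc(F)ccc4F)cc32)cc(OC)c1OC`: 6590 nM
- compound 3 `COc1cc(-n2cnc3ccc(-c4cccc(F)c4)cc32)cc(OC)c1OC`: 2490 nM

Compound 1 gives the lowest number of the three. Removing the methoxy alone gives a 5.8-fold higher number from compound 1 to compound 3 (0.76 log units; beyond the scatter), and exchanging the whole aryl group for 2,5-difluorophenyl gives a 15-fold higher number from compound 1 to compound 2 (1.19 log units; beyond the scatter); between those two, a 2.6-fold lower number from compound 2 to compound 3 (0.42 log units; beyond the scatter). Every change away from the 3-fluoro-4-methoxyphenyl of compound 1 has so far raised the number beyond the scatter.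

Compound 4 `COc1cc(-n2cnc3ccc(-c4cccc(C)c4C)cc32)cc(OC)c1OC` differs from compound 1 as follows: 2,3-dimethylphenyl in place of 3-fluoro-4-methoxyphenyl on an aromatic carbon. The methoxy that is lost here is the same one whose loss cost compound 3 its step from compound 1, and the fluoro is lost too, so the two measured steps from compound 1 both point the same way. The nearest comparisons, compound 3 and compound 2, bracket the expected outcome. Compound 4 is therefore expected to sit well above compound 1, by roughly a 7.0-fold higher number from compound 1 to compound 4 (0.84 log units; beyond the scatter), in the region of compound 3 and compound 2.

Estimate for compound 4 in this assay: 3000 nM, range 1000 nM to 9000 nM.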

Compound 4, half-maximal inhibitory concentration: 3040 nM
Estimate against measurement, compound 4: 1.0-fold (0.01 log units) below, and the stated range covers the measured number.
By their numbers in this assay, from the lowest: compound 1; then compounds 3 and 4 (each within the scatter of the next); then compound 2.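

In this assay, 2,3-dimethylphenyl, which carries neither fluoro nor methoxy, gives a 7.1-fold higher number from compound 1 to compound 4 (0.85 log units; beyond the scatter), so all three replacements of the 3-fluoro-4-methoxyphenyl of compound 1 now raise the number, and this one does so with methyl groups in place of fluoro. Changing 3-fluorophenyl to 2,3-dimethylphenyl gives a 1.2-fold higher number from compound 3 to compound 4 (0.09 log units; within the scatter), so these two groups cannot be told apart here, whereas changing 2,5-difluorophenyl to 2,3-dimethylphenyl gives a 2.2-fold lower number from compound 2 to compound 4 (0.34 log units; beyond the scatter) and leaves 2,5-difluorophenyl as the poorest of the replacements. No supporting data are available to explain any of these steps.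

The compounds shown leave open which feature of the 3-fluoro-4-methoxyphenyl group accounts for the lower number of compound 1. Also open, going by these compounds, is how an ethoxy group, a hydroxyl group or an amine in place of its methoxy would behave.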